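This account rests on a few compounds, and the source may have more. Where it says the series, first, only, none or still open, it means among the compounds named here.

In a functional assay on MCF7 cells (Homo sapiens) for antiproliferative activity, read by sulforhodamine B assay, with a stated time of 48 h (a lower number here means a stronger inhibitor, a higher number a weaker inhibitor), compound 1 (`Cc1cccc(NS(=O)(=O)c2ccc(N3CCNC3=O)cc2)c1`) gives 190 nM, compound 3 (`Cc1ccc(NS(=O)(=O)c2ccc(N3CCNC3=O)cc2)cc1C`) gives 230 nM, and compound 2 (`Cc1ccc(NS(=O)(=O)c2ccc(N3CCNC3=O)cc2)cc1`) gives 610 nM. Compound 2 therefore has the highest number of the three and is the weakest inhibitor here. Compound 4 (`CCCCCCCc1ccc(NS(=O)(=O)c2ccc(N3CCNC3=O)cc2)cc1`) differs from compound 2 in one place: hexyl in place of hydrogen on a saturated chain carbon bound to an aromatic carbon. This is hexyl in place of hydrogen on a saturated chain carbon bound to an aromatic carbon, so methyl becomes heptyl.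

Three measured steps offer some guidance. Swapping 3-methylphenyl for 4-methylphenyl on the sulfonamide nitrogen gave a 3.2-fold higher number from compound 1 to compound 2 (0.51 log units; beyond the scatter). Adding a methyl in place of hydrogen on an aromatic carbon gave a 2.7-fold lower number from compound 2 to compound 3 (0.42 log units; beyond the scatter) and also a 1.2-fold higher number from compound 1 to compound 3 (0.08 log units; within the scatter). These steps show that small methyl changes can shift the number, but none involves a longer chain, so the direction remains uncertain. The change in compound 4 is much larger, and a weaker result seems more likely, so the expected step is a 2.5-fold higher number from compound 2 to compound 4 (0.39 log units; beyond the scatter). For compound 4 in this assay, the estimated value is 1500 nM, with an expected range of 300 nM to 8000 nM.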

Compound 4, half-maximal inhibitory concentration: > 1000 nM
Compound 4: a limit, no number; the forecaster's own chance of this, stated with the estimate: 10%; the middle value is on the limit's open side.
By their numbers in this assay, from the lowest: compounds 1 and 3 (each within the scatter of the next); then compound 2. At a limit, above all of these: compound 4.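

In this assay, among the compounds shown here, compound 4 gives > 1000 nM, which is a limit of the assay and not a number, and this is the first long chain, with heptyl standing where the earlier compounds carry only methyl groups. From the compounds shown here alone, the change from methyl to heptyl gives an at least 1.6-fold higher number from compound 2 to compound 4 (0.21 log units; that floor lies within the scatter), so the smallest rise the limit allows cannot be told apart from ordinary scatter, while the true size of the step stays unknown. Compounds 1, 2 and 3 all give numbers, whereas only the heptyl compound reaches the limit: the limit of > 1000 nM in this assay, at which 1 of the 4 values shown sits.

The compounds shown leave open whether intermediate chains such as ethyl or butyl would give numbers close to that of compound 2 or nearer the limit. Going by these compounds, how a chain ending in an amine or a carboxylic acid would behave also remains open.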